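From fluoro to hydroxy: what to expect

The source may hold more compounds than are shown below. What is called first, only, known or untested is meant among the compounds shown, and "the series" means these compounds.

Measured in a physicochemical assay, read by spectrophotometry, with a stated time of 30 min; a lower number here means a stronger inhibitor, a higher number a weaker inhibitor:
- compound 1 `O=C(CC(c1ccccc1Cl)c1c[nH]c2ccccc12)c1c(O)c2ccccc2oc1=O`: 39.6 ug/mL
- compound 2 `O=C(CC(c1ccc(F)cc1)c1c[nH]c2ccccc12)c1c(O)c2ccccc2oc1=O`: 47.4 ug/mL

Within the data shown here, compound 2 gives 47.4 ug/mL, which cannot be told apart from the only other measured value. Compound 3 `O=C(CC(c1ccc(O)cc1)c1c[nH]c2ccccc12)c1c(O)c2ccccc2oc1=O` has hydroxy in place of fluoro on an aromatic carbon. Among the measured compounds shown here, the one measured step, a 1.2-fold higher number from compound 1 to compound 2 (0.08 log units; within the scatter), swapped 2-chlorophenyl for 4-fluorophenyl and stayed within the scatter. For the measured compounds named here, no measured compound carries hydroxy, so this is weak guidance. On these data alone, the expected change is none beyond the scatter, a 1.2-fold lower number from compound 2 to compound 3 (0.07 log units; within the scatter), and its direction remains open. Compound 3 is estimated at 40 ug/mL, with an expected range of 18 ug/mL to 85 ug/mL.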

Compound 3, half-maximal inhibitory concentration: 58.9 ug/mL
For compound 3 the middle estimate is 1.5-fold (0.17 log units) below the measured one; the measured number falls inside the stated range.
By their numbers in this assay, from the lowest: compounds 1, 2 and 3 (each within the scatter of the next).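

In this assay, putting hydroxy in place of fluoro on an aromatic carbon para to a large group gives a 1.2-fold higher number from compound 2 to compound 3 (0.09 log units; within the scatter) and so brings in a hydrogen-bond donor and acceptor with no change that stands out from the scatter. Replacing the 2-chlorophenyl with 4-hydroxyphenyl gives a 1.5-fold higher number from compound 1 to compound 3 (0.17 log units; within the scatter) and also stays within the scatter, so these three compounds cannot be told apart. No other measurement bears on this result.

On these data alone, whether an amine or a carboxylic acid at this same place would move the number beyond the scatter remains open. So does the effect of any change to the shared core.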